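Swapping the Pyrazine for a Methoxypyrimidine

This account rests on a few compounds, and the source may have more. Where it says the series, first, only, none or still open, it means among the compounds named here.

Three compounds share one core and differ only in the aromatic ring attached to an amine nitrogen in a ring. Compound 1 `COc1cc2nc(N3CCN(c4ncccn4)CC3)nc(N)c2cc1OC` carries a pyrimidin-2-yl there, and in an assay on brain for binding affinity to Adrenergic receptor alpha-1 (Rattus norvegicus) (a higher number here means a weaker inhibitor, a lower number a stronger inhibitor), compound 1 gives 0.26 nM. Compound 2 `COc1cc2nc(N3CCN(c4cccnn4)CC3)nc(N)c2cc1OC` carries a pyridazin-3-yl, and compound 2 gives 0.4 nM. Compound 3 `COc1cc2nc(N3CCN(c4cnccn4)CC3)nc(N)c2cc1OC` carries a pyrazin-2-yl, and compound 3 gives 0.18 nM, the lowest of the three numbers. The nearest of the other numbers lies within the scatter: a 1.4-fold lower number from compound 1 to compound 3 (0.16 log units; within the scatter). The furthest lies beyond it, though only modestly: a 2.2-fold lower number from compound 2 to compound 3 (0.35 log units; beyond the scatter). The remaining step, a 1.5-fold higher number from compound 1 to compound 2 (0.19 log units; within the scatter), shows the same picture of small movements.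

Compound 4 `COc1ccnc(N2CCN(c3nc(N)c4cc(OC)c(OC)cc4n3)CC2)n1` is the next step: 4-methoxypyrimidin-2-yl in place of pyrazin-2-yl on an amine nitrogen in a ring. The measured steps that bear on it are the exchanges of one six-membered aromatic ring with 2 hetero atoms for another, a 1.4-fold lower number from compound 1 to compound 3 (0.16 log units; within the scatter) and a 2.2-fold lower number from compound 2 to compound 3 (0.35 log units; beyond the scatter), both small. Going by the values given here, no measured step adds a methoxy to such a ring, so that part of the change has no precedent here. The expectation is therefore a step of no more than a 1.4-fold higher number from compound 3 to compound 4 (0.14 log units; within the scatter), not beyond the scatter. In this assay compound 4 is expected to give about 0.25 nM, with a range from 0.1 nM to 0.7 nM.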

Compound 4, inhibition constant: 0.19 nM
For compound 4 the middle estimate is 1.3-fold (0.12 log units) above the measured one; the range from low to high includes it.
By their numbers in this assay, from the lowest: compounds 3, 4, 1 and 2 (each within the scatter of the next, the first and the last beyond it).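

Compound 4 gives the first measured case of a substituent on the attached aromatic ring, and adding it to the pyrimidin-2-yl ring of compound 1 stays within the scatter (a 1.4-fold lower number from compound 1 to compound 4 (0.14 log units; within the scatter)). The exchange for pyrazin-2-yl brings in a larger group with one more hydrogen-bond acceptor, yet this step also stays within the scatter (a 1.1-fold higher number from compound 3 to compound 4 (0.02 log units; within the scatter)); only the comparison with the pyridazin-3-yl compound goes beyond it, and modestly (a 2.1-fold lower number from compound 2 to compound 4 (0.32 log units; beyond the scatter)). So in this assay, this position on the amine nitrogen in a ring accepts 4-methoxypyrimidin-2-yl with no measured loss against compound 1 or compound 3, but no measurement available here explains this result.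

As far as these compounds go, it remains open whether the same ring carbon would give a similar number with a longer chain such as butoxy, or with an amine or a carboxylic acid in place of methoxy. It is also unknown whether a methoxy group would behave in the same way on the pyrazin-2-yl or pyridazin-3-yl ring, or on another carbon of the pyrimidin-2-yl ring.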